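Aryl exchange on the ring amine nitrogen: compound 2 to 4

The source may report more compounds than this note shows. Statements on the series, on what has been measured and on what is new or still open speak of the compounds shown alone.

In a functional assay on MGC-803 cells (Homo sapiens) for antiproliferative activity, read by CCK-8 assay, with a stated time of 72 h, tested at 2 uM (on this read-out lower numbers stand for a weaker effect and higher numbers for a stronger effect at the one concentration tested), compound 1 `Nc1ccccc1NC(=O)c1ccc(CSC(=S)N2CCCc3ccccc32)cc1` gives 38.5%. Compound 2 `N#Cc1ccc(N2CCN(C(=S)SCc3ccc(C(=O)Nc4ccccc4N)cc3)CC2)cc1` gives 34.5% in this assay. Compound 3 `Nc1ccccc1NC(=O)c1ccc(CSC(=S)N(Cc2ccccc2)Cc2ccccc2)cc1` gives 11% in this assay. On these three numbers compound 2 lies within the scatter of compound 1 and stands beyond the scatter above compound 3. Compound 4 `Nc1ccccc1NC(=O)c1ccc(CSC(=S)N2CCN(c3cnccn3)CC2)cc1` is not yet measured in this assay. It differs from compound 2 in one place: pyrazin-2-yl in place of 4-cyanophenyl on an amine nitrogen in a ring. Going by the values given here, no step between measured compounds covers this kind of change, so the step expected from compound 2 to compound 4 is small, none beyond the scatter, in either direction. The estimated value for compound 4 in this assay is 31%, with a range from 17% to 45%. This expectation means a step of a number 3.5 percentage points lower from compound 2 to compound 4 (within the scatter).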

Compound 4, a percentage reported as inhibition, at one concentration (the size of the read-out at that concentration, not a potency): 27.1%
Compound 4: middle estimate off by 3.9 percentage points, on the high side; low and high end bracket the measured number.
By their numbers in this assay, from the lowest: compound 3; then compounds 4, 2 and 1 (each within the scatter of the next, the first and the last beyond it).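

In this assay, pyrazin-2-yl in place of 4-cyanophenyl on the amine nitrogen in the ring gives a number 7.4 percentage points lower from compound 2 to compound 4 (within the scatter). This position therefore takes an aromatic ring with 2 hetero atoms in place of the carbon-only ring bearing the nitrile, and the read-out does not separate the two compounds. No measurement at hand bears on this result.

Going by these compounds, it remains open whether a methyl or an acetyl group on this amine nitrogen, with no aromatic ring there, stays within the same range. Reading at one concentration also leaves the potency of compound 2 and compound 4 open.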